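This account rests on a few compounds, and the source may have more. Where it says the series, first, only, none or still open, it means among the compounds named here.

Measured compounds:
Compound 1 `CC(=O)Nc1ccc(CNc2cc(Br)cc3[nH]ncc23)cc1` — in an assay for inhibition of Tryptophan 2,3-dioxygenase (Homo sapiens), with a stated time of 1 h, tested at 10 uM (on this read-out lower numbers stand for less inhibition and higher numbers for more inhibition at the one concentration tested (going by the name of the read-out)), compound 1 gives "not active" (no number reported).
Compound 2 `Nc1ccccc1CNc1cc(Br)cc2[nH]ncc12` — in this assay compound 2 gives "not active" (no number reported).
Compound 3 `FC(F)(F)c1cccc(CNc2cc(Br)cc3[nH]ncc23)c1` — in this assay compound 3 gives 56%.

Compound 1 stands without a single number: it is reported as not active, and compound 2 shares that fate. Only compound 3 returns a number, and its inhibition is a moderate one. Nothing ties these three together as a chain of single changes, so the account can say only what the values themselves show: two members of the series register no inhibition worth a number, one does.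

The step from compound 1 to compound 4 `N#Cc1ccc(CNc2cc(Br)cc3[nH]ncc23)cc1` is described as follows: cyano in place of acetamido on an aromatic carbon. The acetamido group leaves and a cyano group enters on the same aromatic carbon, para to a large group, with the remaining core untouched. For the measured compounds named here, no measured pair of this kind exists, so the size of the step in this assay is not known; given that compound 1 sits at no recorded inhibition and compound 3 reaches 56% with a different substituent, the expectation is a rise of modest size, beyond the scatter, but well short of certain.

Compound 4 is therefore expected to show about 30% in this assay, with a range from 5% to 60%.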

Compound 4, a percentage reported as inhibition, at one concentration (the size of the read-out at that concentration, not a potency): 73%
Estimate against measurement, compound 4: 43 percentage points below; measured number outside the range, above it.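

No step can be read from compound 1 to compound 4: in this assay compound 1 gives "not active" (no number reported) and compound 4 gives 73% and only the second entry is a number. The compounds shown leave open how large the effect of replacing acetamido with cyano is. Nothing given here accounts for the result.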